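A few compounds are considered here, and "the series" means these few. Any claim that something is new, unique, unknown or untested is made for them only; others in the source may bear on it.

Of the compounds shown here, three that share one core have so far been measured in a physicochemical assay for acid dissociation. Compound 1 `CCN(C1=NCCN1)c1c(Br)cccc1Br` gives 11.1. Compound 2 `CCCN(C1=NCCN1)c1c(Br)cccc1Br` gives 11, and compound 3 `CC(C)=CCN(C1=NCCN1)c1c(Br)cccc1Br` gives 10.8. On these numbers compound 3 stands close to both of the others: a number 0.30 log units lower from compound 1 to compound 3 (within the scatter), and a number 0.20 log units lower from compound 2 to compound 3 (within the scatter). The step between the first two is just as small, a number 0.10 log units lower from compound 1 to compound 2 (within the scatter). Every change made so far has touched the group carried by the nitrogen on the aromatic ring, and none has moved the number beyond the scatter.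

Compound 4 `Brc1cccc(Br)c1N(C1=NCCN1)C1CCCCC1` has not yet been measured. It differs from compound 3 at that same nitrogen: cyclohexyl in place of 3-methylbut-2-en-1-yl on a nitrogen on an aromatic ring. The two steps that bear on this change, a number 0.30 log units lower from compound 1 to compound 3 (within the scatter) and a number 0.20 log units lower from compound 2 to compound 3 (within the scatter), each exchanged one group for another at the nitrogen on the aromatic ring without any shift beyond the scatter. The expected outcome is therefore a step no larger than the scatter, a number 0.10 log units higher from compound 3 to compound 4 (within the scatter). Compound 4 is thus estimated at 10.9, within a range from 10.5 to 11.3.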

Compound 4, acid dissociation constant: 11.3
For compound 4 the middle estimate is 0.40 log units below the measured one; measured number inside the range.
By their numbers in this assay, from the lowest: compounds 3, 2, 1 and 4 (each within the scatter of the next, the first and the last beyond it).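

In this assay, this nitrogen on an aromatic ring now gives its first step beyond the scatter, a number 0.50 log units higher from compound 3 to compound 4 (beyond the scatter), when cyclohexyl, with its six-membered ring of carbon only, replaces the open 3-methylbut-2-en-1-yl with its double bond. Cyclohexyl does not stand apart from the two plain chains, however, with a number 0.30 log units higher from compound 2 to compound 4 (within the scatter) and a number 0.20 log units higher from compound 1 to compound 4 (within the scatter), so the change separates only the two ends of this short series, and only modestly. Nothing available accounts for that one larger step.

The compounds shown leave open how a smaller ring such as cyclopropyl, a longer chain such as hexyl, or a chain ending in an amine would read at this nitrogen. They also leave open whether the same step would appear with chlorine in place of the bromines on the shared core.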